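Acrylamide in place of hydrogen on the aniline nitrogen

This account rests on a few compounds, and the source may have more. Where it says the series, first, only, none or still open, it means among the compounds named here.

Compound 1 `CC(=O)Nc1cccc(C(=O)/C=C2/C(=O)Nc3ccccc32)c1` gives 14100 nM in a functional assay on SGC-7901 cells (Homo sapiens) for inhibition, read by MTT assay, with a stated time of 72 h; a higher number here means a weaker inhibitor, a lower number a stronger inhibitor. Compound 2 `Nc1cccc(C(=O)/C=C2/C(=O)Nc3ccccc32)c1` gives 14400 nM in this assay.

Compound 2 has the highest of the two numbers, but the step of a 1.0-fold higher number from compound 1 to compound 2 (0.01 log units; within the scatter) is within the scatter, so the two compounds are indistinguishable. Compound 3 `C=CC(=O)Nc1cccc(C(=O)/C=C2/C(=O)Nc3ccccc32)c1` is not yet measured. It differs from compound 2 by vinylcarbonyl in place of hydrogen on a nitrogen on an aromatic ring. Among the measured compounds shown here, the only step that bears on this change, a 1.0-fold higher number from compound 1 to compound 2 (0.01 log units; within the scatter), swapped an acetyl for hydrogen and gave no change beyond the scatter, so a change from amino to (vinylcarbonyl)amino is expected to stay near compound 2, with a step of a 1.3-fold lower number from compound 2 to compound 3 (0.12 log units; within the scatter). Compound 3 is thus estimated at 11000 nM, between 4000 nM and 30000 nM.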

Compound 3, half-maximal inhibitory concentration: 5700 nM
Estimate against measurement, compound 3: 1.9-fold (0.29 log units) above; the range from low to high includes it.
By their numbers in this assay, from the lowest: compound 3; then compounds 1 and 2 (each within the scatter of the next).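

Swapping acetyl for hydrogen on this nitrogen gave no change beyond the scatter, but in this assay the vinylcarbonyl group does give a readable step (a 2.5-fold lower number from compound 2 to compound 3 (0.40 log units; beyond the scatter)). The step from the acetyl compound (a 2.5-fold lower number from compound 1 to compound 3 (0.39 log units; beyond the scatter)) shows that, among these compounds, the gain goes with vinyl in place of methyl on a carbonyl carbon, not with the carbonyl alone. Nothing available explains this difference. Still open, from the compounds shown here alone, is whether the double bond matters or only the size of the group: an ethyl group on the same carbonyl carbon would separate the two.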